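The source may hold more compounds than are shown below. What is called first, only, known or untested is meant among the compounds shown, and "the series" means these compounds.

Among the measured compounds shown here, in a functional assay on the whole organism with Mus musculus as the target (a lower number here means that less compound is needed, a higher number that more compound is needed for the effect), compound 1 `COc1cc2c(cc1OC)C(c1ccc(Cl)cc1)=NNC(=O)C2` gives 102 umol/kg, the second highest of the three numbers measured so far. Compound 2 `COc1cc2c(cc1OC)C(c1ccc(Br)cc1)=NN(C)C(=S)C2` gives 105 umol/kg, which lies within the scatter of compound 1, while compound 3 `COc1cc2c(cc1OC)C(c1ccc(N)cc1)=NN(C)C(=S)C2` gives 29.8 umol/kg, a clearly lower number. Compound 4 `COc1cc2c(cc1OC)C(c1cccc(N)c1)=NNC(=O)C2` differs from compound 1 in one place: 3-aminophenyl in place of 4-chlorophenyl on a carbon with a double bond to nitrogen. For the measured compounds named here, only one measured step bears on this change: a 3.5-fold lower number from compound 2 to compound 3 (0.55 log units; beyond the scatter). That step was seen on a core that differs from the core of compound 1, and in compound 4 the amino group arrives as 3-aminophenyl, so its transfer is uncertain. A lowering of similar or somewhat smaller size is nevertheless expected, a 2.0-fold lower number from compound 1 to compound 4 (0.31 log units; beyond the scatter). Compound 4 is therefore estimated at 50 umol/kg, with a range from 20 umol/kg to 120 umol/kg.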

Compound 4, dose for half-maximal effect: 19.3 umol/kg
Estimate against measurement, compound 4: 2.6-fold (0.41 log units) above; the whole stated range lies above it.
By their numbers in this assay, from the lowest: compounds 4 and 3 (each within the scatter of the next); then compounds 1 and 2 (each within the scatter of the next).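

The change gives a 5.3-fold lower number from compound 1 to compound 4 (0.72 log units; beyond the scatter) in this assay, so an amino-bearing phenyl on this carbon goes with a lower number on the core of compound 1 as well, not only on the core of compound 3. This step replaces chloro with amino and also moves the substituent around the phenyl ring, so it cannot show which of the two matters. Nothing available explains the lower number. Still open, as far as these compounds go, is how 3-chlorophenyl or 4-aminophenyl would compare on this core, which would separate the two changes, and whether a dimethylamino group would keep the lower number.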